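Aryl ether series: from 3,4-dichlorophenyl to 4-methylphenyl

The source may hold more compounds than are shown below. What is called first, only, known or untested is meant among the compounds shown, and "the series" means these compounds.

Measured in a functional assay on A549 cells (Homo sapiens) for antiproliferative activity, read by MTT assay, with a stated time of 72 h; on this read-out higher numbers stand for weaker inhibition and lower numbers for stronger inhibition:
- compound 1 `NC1=NC2(CCOCC2)N(OCCCOc2ccccc2Cl)C(N)=N1`: 2700 nM
- compound 2 `NC1=NC2(CCOCC2)N(OCCCOc2ccc(F)cc2)C(N)=N1`: 1060 nM
- compound 3 `NC1=NC2(CCOCC2)N(OCCCOc2ccc(Cl)c(Cl)c2)C(N)=N1`: 790 nM

Compound 3, at 790 nM, cannot be separated from the 4-fluorophenyl analogue, with a 1.3-fold lower number from compound 2 to compound 3 (0.13 log units; within the scatter) falling within the scatter. It stands clear only of the 2-chlorophenyl analogue, with a 3.4-fold lower number from compound 1 to compound 3 (0.53 log units; beyond the scatter) being modest.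

Compound 4 `Cc1ccc(OCCCON2C(N)=NC(N)=NC23CCOCC3)cc1` is unmeasured and carries 4-methylphenyl in place of 3,4-dichlorophenyl on an oxygen on a saturated carbon.

All three measured steps change the aryl group at this same place, and they are small: a 2.5-fold lower number from compound 1 to compound 2 (0.41 log units; beyond the scatter), a 3.4-fold lower number from compound 1 to compound 3 (0.53 log units; beyond the scatter) and a 1.3-fold lower number from compound 2 to compound 3 (0.13 log units; within the scatter). Within the data shown here, none of the measured compounds carries a 4-methylphenyl group. By name, the closest measured group is the 4-fluorophenyl of compound 2 at 1060 nM, so a value near that of compound 2 is expected. In this assay, a small move toward a higher number is therefore expected, probably not beyond the scatter, though a value near that of compound 1 at 2700 nM cannot be excluded.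

The estimate corresponds to an expected 1.4-fold higher number from compound 3 to compound 4 (0.14 log units; within the scatter).

For compound 4 the estimated value is 1100 nM, with an expected range of 520 nM to 2400 nM.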

Compound 4, half-maximal inhibitory concentration: 1060 nM
Beside the measured number, compound 4's estimate is 1.0-fold (0.02 log units) above it; measured number inside the range.
By their numbers in this assay, from the lowest: compounds 3, 2 and 4 (each within the scatter of the next); then compound 1.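

In this assay, compound 4 shows that this place on an oxygen on a saturated carbon tolerates an aryl group with no halogen: methyl in place of fluoro on an aromatic carbon gives no change at the digits printed from compound 2 to compound 4 (within the scatter), and 4-methylphenyl in place of 3,4-dichlorophenyl gives a 1.3-fold higher number from compound 3 to compound 4 (0.13 log units; within the scatter). The 2-chlorophenyl group of compound 1 now stands apart from a third group, with a 2.5-fold lower number from compound 1 to compound 4 (0.41 log units; beyond the scatter), while 4-fluorophenyl, 3,4-dichlorophenyl and 4-methylphenyl cannot be separated from one another, although this rests on a single compound on the 2-chlorophenyl side. Nothing available explains why these three groups give such similar numbers or why compound 1 differs from them.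

From the compounds shown here alone, it remains open whether a 2-methylphenyl group would stand apart as the 2-chlorophenyl group does, and what an amine or a carboxylic acid on the aryl ring, or a longer chain in place of the present one, would do in this assay. These four compounds vary only in the aryl group, so they say nothing about changes to the shared core.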